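Benzyl on the sulfur: stepping from compound 3 to compound 4

A few compounds are considered here, and "the series" means these few. Any claim that something is new, unique, unknown or untested is made for them only; others in the source may bear on it.

Measured so far in a functional assay on the whole organism for activation, with Mus musculus as the target, with stated times of 14 days and 2 h, at a dose of 15 mg/kg by the intravenous route; a lower number here means a weaker effect, a higher number a stronger effect of the compound at the dose given:
compound 1 `Nc1ncnc2c1nc(O)n2[C@@H]1O[C@@H]2COP(=O)(O)O[C@H]2[C@H]1O` gives 114%;
compound 2 `[N-]=[N+]=Nc1nc2c(N)ncnc2n1[C@@H]1O[C@@H]2COP(=O)(O)O[C@H]2[C@H]1O` gives 594%;
compound 3 `Nc1ncnc2c1nc(S)n2[C@@H]1O[C@@H]2COP(=O)(O)O[C@H]2[C@H]1O` gives no result reported.

Compound 3 stands nowhere on the numbers shown: no single value exists for it, so its place relative to compound 1 and compound 2 cannot be stated. Among the measured compounds shown here, the only step measured in this assay is a number 480 percentage points higher from compound 1 to compound 2 (beyond the scatter), a large increase that follows a change on an aromatic carbon of the shared core.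

Compound 4 `Nc1ncnc2c1nc(SCc1ccccc1)n2[C@@H]1O[C@@H]2COP(=O)(O)O[C@H]2[C@H]1O` differs from compound 3 by benzyl in place of hydrogen on a sulfur. For the measured compounds named here, this change, sulfanyl to benzylsulfanyl, touches a different part of the molecule than the step from compound 1 to compound 2, and no measured step in this assay involves a substituent on a sulfur. The step from compound 1 to compound 2 therefore bears on it only as a sign that substitution at this position of the core can move the read-out strongly; it gives no direction for a benzyl group entering on sulfur. No step size can be stated for the change from compound 3 to compound 4.

For compound 4 the activity is therefore estimated near the value of compound 1, at 160%, with a broad range from 60% to 420%.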

Compound 4, a percentage reported as activity, at one dose (the size of the read-out at that dose, not a potency): 183%
Compound 4: middle estimate off by 23 percentage points, on the low side; measured number inside the range.
By their numbers in this assay, from the lowest: compound 1; then compound 4; then compound 2.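

Working notes on the substituent at this aromatic carbon of the shared core: in this assay three groups now have numbers, and benzylsulfanyl lies between the other two. Against hydroxy, the change to benzylsulfanyl gives a number 69 percentage points higher from compound 1 to compound 4 (beyond the scatter), and against azido it gives a number 411 percentage points lower from compound 2 to compound 4 (beyond the scatter), so the position carries a group attached through sulfur with a read-out clearly above that of hydroxy yet far short of that of azido. No supporting measurement is available to account for this order of the three groups.

Going by these compounds, the step from compound 3 to compound 4 cannot be read, so what the benzyl adds to the sulfanyl group on its own remains open, as does any effect of the sulfur atom apart from the benzyl. Also open, on these data alone, is where a simple amine on this aromatic carbon, or a methyl or a longer phenylethyl chain on the sulfur, would fall relative to hydroxy, benzylsulfanyl and azido.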